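Replacing the basic side chain of compound 1 with a triazole bearing a diol

A few compounds are considered here, and "the series" means these few. Any claim that something is new, unique, unknown or untested is made for them only; others in the source may bear on it.

Measured compounds:
compound 1 `CN1CCN(CCCCCn2c3c(c4ccccc42)C(=O)c2c[n+]([O-])c4ccccc4c2C3=O)CC1` 2270 nM
compound 2 `O=C1c2c[n+]([O-])c3ccccc3c2C(=O)c2c1c1ccccc1n2Cc1cn([C@H]2C[C@H](O)[C@@H](CO)O2)nn1` 580 nM
compound 3 `O=C1c2c[n+]([O-])c3ccccc3c2C(=O)c2c1c1ccccc1n2CCCN1CCC(O)CC1` 280 nM

In a functional assay on MDA-MB-231 cells (Homo sapiens) for cytotoxicity, read by MTT assay, with a stated time of 72 h (on this read-out lower numbers stand for stronger inhibition and higher numbers for weaker inhibition), compound 1 gives the highest number of the three. Compound 4 `O=C1c2c[n+]([O-])c3ccccc3c2C(=O)c2c1c1ccccc1n2Cc1cn(C[C@H](O)CO)nn1` differs from it by 1-(2,3-dihydroxypropyl)-1H-1,2,3-triazol-4-yl in place of 4-(4-methylpiperazin-1-yl)butyl on a saturated chain carbon bound to an aromatic nitrogen. Within the data shown here, the one measured step at the same kind of position, an 8.1-fold lower number from compound 1 to compound 3 (0.91 log units; beyond the scatter), shows that changing the chain end from compound 1 gives a lower number. Compound 2, which also carries a triazole with hydroxyl groups on the chain attached to the aromatic nitrogen, gives 580 nM, while compound 1 gives 2270 nM. Compound 4 is therefore expected to show a lower number than compound 1, with a step of about a 3.5-fold lower number from compound 1 to compound 4 (0.54 log units; beyond the scatter) in this assay. The estimate for compound 4 is 650 nM, in a range from 250 nM to 1700 nM.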

Compound 4, half-maximal inhibitory concentration: 1310 nM
Estimate against measurement, compound 4: 2.0-fold (0.30 log units) below, and the stated range covers the measured number.
By their numbers in this assay, from the lowest: compound 3; then compound 2; then compounds 4 and 1 (each within the scatter of the next).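

In this assay, 1-(2,3-dihydroxypropyl)-1H-1,2,3-triazol-4-yl in place of 4-(4-methylpiperazin-1-yl)butyl gives a 1.7-fold lower number from compound 1 to compound 4 (0.24 log units; within the scatter), so this change does not clearly separate the two chain ends. What the triazole carries does count, with 2,3-dihydroxypropyl in place of 4-hydroxy-5-(hydroxymethyl)oxolan-2-yl giving a 2.3-fold higher number from compound 2 to compound 4 (0.35 log units; beyond the scatter), and the 4-hydroxypiperidin-1-yl chain end remains ahead, with a 4.7-fold higher number from compound 3 to compound 4 (0.67 log units; beyond the scatter). Nothing shown explains these differences. Going by these compounds, whether an amine or a carboxylic acid on the triazole, or a longer chain linking the triazole to the aromatic nitrogen, would shift the number remains open.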